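Trifluoromethoxy for Methoxy in a Quinolone Ester Series

The source may hold more compounds than are shown below. What is called first, only, known or untested is meant among the compounds shown, and "the series" means these compounds.

Of the compounds shown here, three built on one shared core have been tested in an ADME assay on Raji cells (Homo sapiens) for cytotoxicity, read by luminescence, with a stated time of 72 h; on this read-out lower numbers stand for an effect already at smaller amounts and higher numbers for an effect only at larger amounts of compound. Compound 1, `CCOC(=O)c1c(-c2cccc(OC(F)(F)F)c2)[nH]c2cc(OC)ccc2c1=O`, carries a methoxy on the ring of the core. In this assay compound 1 reaches only the limit, giving > 21500 nM. Compound 2, `CCOC(=O)c1c(-c2cccc(OC(F)(F)F)c2)[nH]c2cc(OC(F)(F)F)ccc2c1=O`, differs from compound 1 by trifluoromethyl in place of methyl on an oxygen on an aromatic ring. In this assay compound 2 likewise reaches only the limit, giving > 21500 nM. The step that the two limits leave unreadable from compound 1 to compound 2 therefore cannot be read, since (the limit of > 21500 nM in this assay, at which 3 of the 3 values shown sit).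

Compound 3, `CCOC(=O)c1c(-c2cccc(OC)c2)[nH]c2cc(C(F)(F)F)ccc2c1=O`, carries a methoxy on the pendant ring and a trifluoromethyl on the core; how its core differs from that of compound 1 is not broken down here. In this assay compound 3 also stands at the limit, giving > 21500 nM.

Compound 4, `CCOC(=O)c1c(-c2cccc(OC(F)(F)F)c2)[nH]c2cc(C(F)(F)F)ccc2c1=O`, has not yet been tested. It differs from compound 3 by trifluoromethyl in place of methyl on an oxygen on an aromatic ring, which is the same change as that from compound 1 to compound 2, at the same place. Because (the limit of > 21500 nM in this assay, at which 3 of the 3 values shown sit), the earlier step gives no measurable size to carry over. The expectation for compound 4 is therefore that the step that the limit leaves unreadable from compound 3 to compound 4 leaves it, like the other three, at or beyond the limit of this assay. Compound 4 is estimated at 30000 nM, with a range from 15000 nM to 80000 nM.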

Compound 4, half-maximal effective concentration: > 21500 nM
Compound 4 was reported as a limit; the forecaster's own chance of this, stated with the estimate: 85%; the middle value lies beyond the limit too.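

None of the steps from compound 1, compound 2 or compound 3 to compound 4 can be read in this assay, because all of these compounds stand at one and the same limit: the limit of > 21500 nM in this assay, at which 4 of the 4 values shown sit.

The compounds shown leave open how large the change from methoxy to trifluoromethoxy is in this read-out, and whether any change on the shared core moves it at all.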